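From 2,4-dichlorophenyl to 4-hydroxyphenyl: an expected loss

A few compounds are considered here, and "the series" means these few. Any claim that something is new, unique, unknown or untested is made for them only; others in the source may bear on it.

Measured in a functional assay on DU-145 cells (Homo sapiens) for inhibition; a higher number here means a weaker inhibitor of growth, a lower number a stronger inhibitor of growth:
Compound 1 `O=S(=O)(/C=C/c1ccc(Cl)cc1)Cc1ccc(Nc2ncnc3ccccc23)cc1`: > 100000 nM (a limit)
Compound 2 `O=S(=O)(/C=C/c1ccc(Cl)cc1Cl)Cc1ccc(Nc2ncnc3ccccc23)cc1`: 3000 nM

Among the compounds with values here, compound 2, at 3000 nM, holds the only actual number so far. Compound 1 reads > 100000 nM, which is a limit of the assay and not a number.

The next compound is compound 3 `O=S(=O)(/C=C/c1ccc(O)cc1)Cc1ccc(Nc2ncnc3ccccc23)cc1`, and its difference from compound 2 is 4-hydroxyphenyl in place of 2,4-dichlorophenyl on a double-bonded chain carbon bound to a double-bonded chain carbon. In short, 4-hydroxyphenyl stands in place of 2,4-dichlorophenyl on a double-bonded chain carbon bound to a double-bonded chain carbon.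

Within the data shown here, one measured step bears on this, though only in part. It is an at least 33-fold lower number from compound 1 to compound 2 (1.52 log units; beyond the scatter), a large step that came with chloro in place of hydrogen on an aromatic carbon. Among the measured compounds shown here, compound 3 carries no chlorine at all, and no measured compound carries 4-hydroxyphenyl, so that step guides the direction more than the size. Compound 3 is therefore expected to be a weaker inhibitor in this assay, beyond the scatter, with an estimated 6.7-fold higher number from compound 2 to compound 3 (0.82 log units; beyond the scatter). For compound 3 the estimated value is 20000 nM, with an expected range from 2500 nM to 100000 nM.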

Compound 3, concentration for 50% growth inhibition: 19000 nM
Estimate against measurement, compound 3: 1.1-fold (0.02 log units) above; low and high end bracket the measured number.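

In this assay, the position on a double-bonded chain carbon now carries a second group with an actual number, and 4-hydroxyphenyl in place of 2,4-dichlorophenyl weakens growth inhibition, with a 6.3-fold higher number from compound 2 to compound 3 (0.80 log units; beyond the scatter). Hydroxy in place of chloro on an aromatic carbon goes the other way, with an at least 5.2-fold lower number from compound 1 to compound 3 (0.72 log units; beyond the scatter), so chlorine count alone does not order these three compounds: compound 2, with the most chlorine, is the strongest, but compound 3, with none, goes against a simple trend by standing on the stronger side of compound 1. That second step gives only a lower bound on the change, since compound 1 stands at a limit of the assay and not at a number: the limit of > 100000 nM in this assay, at which 1 of the 3 values shown sits.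

The compounds shown do not separate how much of the gap between the two measured compounds belongs to the loss of the chloro groups and how much to the arrival of the hydroxy group. Going by these compounds, it also remains open how an amine, a methoxy group or a carboxylic acid on the same phenyl ring would compare with hydroxy.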